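The source may report more compounds than this note shows. Statements on the series, on what has been measured and on what is new or still open speak of the compounds shown alone.

Compound 1 `COc1ccc2nc(N(Cc3cc(-c4ccc(OC(F)(F)F)cc4)no3)c3nc4ccc(F)cc4s3)sc2c1` gives 17400 nM in a functional assay on MCF7 cells (Homo sapiens) for antiproliferative activity, read by MTT assay; a lower number here means a stronger inhibitor, a higher number a weaker inhibitor. Compound 2 `COc1ccc2nc(N(Cc3cc(-c4cc(OC)c(OC)c(OC)c4)no3)c3nc4ccc(F)cc4s3)sc2c1` gives 26600 nM. Compound 3 `FC(F)(F)Sc1ccc(-c2cc(CN(c3ncccn3)c3nc4ccccc4s3)on2)cc1` gives 17200 nM.

Compound 3 shows the lowest of the three numbers, but its gaps to compound 1 and compound 2 both lie within the scatter, so the three stand together. Compound 4 `FC(F)(F)Oc1ccc(-c2cc(CN(c3ncccn3)c3nc4ccccc4s3)on2)cc1` differs from compound 3 by trifluoromethoxy in place of (trifluoromethyl)sulfanyl on an aromatic carbon. Going by the values given here, no measured step changes this pair of groups; the only step in hand, a 1.5-fold higher number from compound 1 to compound 2 (0.18 log units; within the scatter), concerns other groups on a different core and stayed within the scatter. With nothing pointing either way, the step is expected to be a 1.0-fold lower number from compound 3 to compound 4 (0.01 log units; within the scatter), no larger than the scatter. Compound 4 is therefore estimated at 17000 nM in this assay, between 7000 nM and 40000 nM.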

Compound 4, half-maximal inhibitory concentration: 14800 nM
For compound 4 the middle estimate is 1.1-fold (0.06 log units) above the measured one, within the range that was stated.
By their numbers in this assay, from the lowest: compounds 4, 3, 1 and 2 (each within the scatter of the next).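

In this assay, trifluoromethoxy in place of (trifluoromethyl)sulfanyl, on an aromatic carbon para to a large group, gives a 1.2-fold lower number from compound 3 to compound 4 (0.07 log units; within the scatter) and so leaves the number within the scatter at this position. The earlier step, a 1.5-fold higher number from compound 1 to compound 2 (0.18 log units; within the scatter), concerned other groups on a different core and did not test this exchange. No measurement at hand bears on this result.

Going by these compounds, whether an amine or a carboxylic acid on that aromatic carbon would move the number beyond the scatter stays open, as does whether this exchange would read the same on the core of compound 1.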